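Swapping the benzyl group on the ring amine of compound 1

This account rests on a few compounds, and the source may have more. Where it says the series, first, only, none or still open, it means among the compounds named here.

Measured compounds in a functional assay on MKN-74 cells (Homo sapiens) for antiproliferative activity, with a stated time of 24 h; on this read-out higher numbers stand for weaker inhibition and lower numbers for stronger inhibition:
- compound 1 `N#Cc1ccccc1CN1CCc2c(sc(NC(=O)c3ccccc3Cl)c2C(N)=O)C1`: 9500 nM
- compound 2 `NC(=O)c1c(NC(=O)c2ccc(C(F)(F)F)cc2)sc2c1CCN(Cc1ccc(Cl)cc1Cl)C2`: 10900 nM
- compound 3 `Cc1ccc(C(=O)Nc2sc3c(c2C(N)=O)CCN(Cc2ccc(Cl)cc2Cl)C3)cc1`: 25500 nM

Among these three, compound 1 gives the lowest number, with compound 2 close by, within the scatter, and compound 3 further away, beyond the scatter. Within the data shown here, the one step that can be read directly is from compound 2 to compound 3, where methyl replaces trifluoromethyl on an aromatic carbon of the amide side: a 2.3-fold higher number from compound 2 to compound 3 (0.37 log units; beyond the scatter).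

Compound 4 `NC(=O)c1c(NC(=O)c2ccccc2Cl)sc2c1CCN(C(=S)Nc1ccccc1F)C2` keeps the amide side of compound 1 unchanged and instead alters the ring amine: a group of 10 heavy atoms (7 carbon, 1 nitrogen, 1 fluorine, 1 sulfur; one six-membered aromatic ring of carbon only) in place of a group of 9 heavy atoms (8 carbon, 1 nitrogen; one six-membered aromatic ring of carbon only), on an amine nitrogen in a ring

Among the measured compounds shown here, no measured pair shows a change at this amine nitrogen, so the step from compound 2 to compound 3, which sits on a different part of the molecule, does not bear on it. With nothing to point one way or the other, the expected step from compound 1 to compound 4 is no change at the digits printed from compound 1 to compound 4 (within the scatter), meaning no change beyond the scatter, with a wide range to reflect the lack of comparable evidence. On that basis compound 4 is expected to give about 9500 nM in this assay, estimated between 3000 nM and 30000 nM.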

Compound 4, half-maximal inhibitory concentration: 12600 nM
Compound 4: the middle estimate sits 1.3-fold (0.12 log units) below what was measured; measured number inside the range.
By their numbers in this assay, from the lowest: compounds 1, 2 and 4 (each within the scatter of the next); then compound 3.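

In this assay, the group on the amine nitrogen of the ring can be exchanged wholesale with little consequence: replacing 2-cyanobenzyl with the group bearing fluorine and sulfur gives a 1.3-fold higher number from compound 1 to compound 4 (0.12 log units; within the scatter). Among these compounds, this is the first direct reading at this position, and it shows that the triple bond of the 2-cyanobenzyl group can be lost, and a hydrogen-bond donor gained, without moving the number beyond the scatter. Nothing available explains why the read-out holds steady across so different a pair of groups.

This is a single pair, so the compounds shown leave open whether the position is indifferent to its substituent in general or whether these two groups merely happen to match, each keeping an aromatic ring of carbon at about the same size. A much smaller group such as methyl, a bare hydrogen on the nitrogen, or a chain ending in a carboxylic acid would test whether that aromatic ring is needed at all.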